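This account rests on a few compounds, and the source may have more. Where it says the series, first, only, none or still open, it means among the compounds named here.

In an assay on cells for inhibition of Palmitoleoyl-protein carboxylesterase NOTUM variant C330S (Homo sapiens), read by fluorescence, with a stated time of 40 min (a higher number here means a weaker inhibitor, a lower number a stronger inhibitor), compound 1 `O=C(O)C1CCN(c2cccc(C(F)(F)F)c2F)C1` gives 6800 nM, while compound 2 `O=C(Nc1ccccc1)C1CCN(c2ccc(Cl)c(C(F)(F)F)c2)C1` gives 1000 nM. Compound 2 thus holds the lowest of the two numbers in this assay, and compound 1 lies beyond the scatter from it. Compound 3 `O=C(C1CCN(c2ccc(Cl)c(C(F)(F)F)c2)C1)N1CC2COCC2C1` is compound 2 changed as follows: a group of 8 heavy atoms (6 carbon, 1 nitrogen, 1 oxygen; 2 five-membered non-aromatic rings with 1 hetero atom each) in place of a group of 7 heavy atoms (6 carbon, 1 nitrogen; one six-membered aromatic ring of carbon only), on a carbonyl carbon. Going by the values given here, no measured pair shows this kind of change, so the step is expected to be modest, most likely toward a higher number, though a result within the scatter is also possible; the expected step is a 2.0-fold higher number from compound 2 to compound 3 (0.30 log units; within the scatter). Compound 3 is estimated at 2000 nM, within 400 nM to 10000 nM.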

Compound 3, half-maximal inhibitory concentration: 3100 nM
Beside the measured number, compound 3's estimate is 1.6-fold (0.19 log units) below it, within the range that was stated.
By their numbers in this assay, from the lowest: compound 2; then compound 3; then compound 1.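

In this assay replacing anilino on the carbonyl carbon with the group of 2 five-membered non-aromatic rings gives a 3.1-fold higher number from compound 2 to compound 3 (0.49 log units; beyond the scatter) and so shows that the number responds to this place. The amide still gives a measurable number without the aromatic ring or its hydrogen-bond donor. No measurement shown accounts for this step. The change removes that ring and donor and adds an acceptor all at once, so the compounds shown cannot separate these parts. From the compounds shown here alone, how morpholine or benzylamine would read on this carbonyl carbon remains open.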